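Furan to Thiophene on a Shared Core

The compounds below may be only part of what the source reports. "The series", "measured", "known", "first", "only" and "open" are said of these compounds alone.

Measured compounds and their values in a functional assay on the whole organism (plasma, strain Sprague-Dawley) with Rattus norvegicus as the target, with a stated time of 2 h, at a dose of 25 mg/kg by the oral route; on this read-out lower numbers stand for a weaker effect and higher numbers for a stronger effect at the one dose given:
compound 1, `c1ccc(C(/N=C2\CCCCN2)C2CC2)cc1`: 23%
compound 2, `c1ccc(C(/N=C2\CCCCCCN2)C2CC2)cc1`: 26%
compound 3, `c1ccc(C(/N=C2\CCCCN2)c2ccco2)cc1`: 10%

Among the compounds with values here, compound 3 stands lowest of the three numbers in this assay; its nearest neighbour is compound 1, and the step of a number 13 percentage points lower from compound 1 to compound 3 (beyond the scatter) is the only one-place change measured so far. Compound 1 and compound 2 differ in the ring that carries the double-bonded nitrogen, and their two values lie within the usual scatter of each other, so nothing is said of their order.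

Compound 4, `c1ccc(C(/N=C2\CCCCN2)c2cccs2)cc1`, differs from compound 3 by thiophen-2-yl in place of furan-2-yl on a saturated chain carbon bound to an aromatic carbon and a double-bonded nitrogen. Within the data shown here, no measured step bears directly on this exchange: the one step in hand concerns furan-2-yl entering in place of cyclopropyl, not thiophen-2-yl entering in place of furan-2-yl. Since the two groups are alike in what is counted, the step of a number 5 percentage points higher from compound 3 to compound 4 (within the scatter) is expected to stay within the scatter, with no clear direction. Compound 4 is therefore estimated to give 15% in this assay, within a range from 0% to 35%.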

Compound 4, a percentage reported as inhibition, in the whole organism at one dose (the size of the read-out at that dose, not a potency): 31%
For compound 4 the middle estimate is 16 percentage points below the measured one; the range from low to high includes it.
By their numbers in this assay, from the lowest: compound 3; then compounds 1, 2 and 4 (each within the scatter of the next).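

In this assay, furan-2-yl and thiophen-2-yl match in everything counted except oxygen for sulfur, yet the exchange on the saturated chain carbon gives a number 21 percentage points higher from compound 3 to compound 4 (beyond the scatter) on the shared core. Thiophen-2-yl in place of cyclopropyl gives a number 8 percentage points higher from compound 1 to compound 4 (within the scatter) and so cannot be told apart from it at this place, which leaves furan-2-yl as the one group of the three that stands apart from the other two. No measurement bears on why the single ring atom matters here.

Going by these compounds, whether a phenyl or a thiophen-3-yl group at this place would stand with thiophen-2-yl or with furan-2-yl stays open. So does whether thiophen-2-yl would hold its value on the ring of compound 2.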